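The source may report more compounds than this note shows. Statements on the series, on what has been measured and on what is new or still open speak of the compounds shown alone.

Measured so far in a functional assay on HL-60 cells (Homo sapiens) for cytotoxicity, read by MTT assay, with a stated time of 24 h; on this read-out higher numbers stand for weaker inhibition and lower numbers for stronger inhibition:
compound 1 `COC(=O)/C(=C\c1ccc(OC(=O)c2cc(OC)cc(OC)c2)cc1)Sc1ccnc2cc(Cl)ccc12` gives 19000 nM
compound 2 `COC(=O)/C(=C\c1ccc(OC(=O)c2ccc(OC)cc2OC)cc1)Sc1ccnc2cc(Cl)ccc12` gives 7640 nM
compound 3 `COC(=O)/C(=C\c1ccc(OC(=O)c2cccc(OC)c2OC)cc1)Sc1ccnc2cc(Cl)ccc12` gives 13000 nM

Compound 1 has the highest number of the three. Compound 3 sits nearest to it, and that gap is within the usual scatter, so the two cannot be told apart. Compound 2 lies furthest away: a 2.5-fold lower number from compound 1 to compound 2 (0.40 log units; beyond the scatter). All three share one core and differ only in the way the methoxy groups are placed on the ring attached to the carbonyl.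

Compound 4 `COC(=O)/C(=C\c1ccc(OC(=O)c2cc(OC)c(OC)c(OC)c2)cc1)Sc1ccnc2cc(Cl)ccc12` is not yet measured. Compared with compound 1 the change is methoxy in place of hydrogen on an aromatic carbon. This is not a relocation of methoxy groups, as in the measured steps, but the addition of a third one.

Going by the values given here, the steps that bear on it are the two that alter the same ring in compound 1: a 2.5-fold lower number from compound 1 to compound 2 (0.40 log units; beyond the scatter) and a 1.5-fold lower number from compound 1 to compound 3 (0.16 log units; within the scatter). Both moved the number downward, one modestly beyond the scatter and one within it. Among the compounds with values here, no measured step adds a group to this ring, so the direction for compound 4 is expected to be similar or flat, a small move to a lower number at most. Compound 4 is therefore estimated at 12000 nM in this assay, with a range from 5000 nM to 30000 nM. That estimate corresponds to an expected step of a 1.6-fold lower number from compound 1 to compound 4 (0.20 log units; within the scatter).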

Compound 4, half-maximal inhibitory concentration: 4240 nM
Compound 4: the middle estimate sits 2.8-fold (0.45 log units) above what was measured, and the stated range ends above it.
By their numbers in this assay, from the lowest: compounds 4, 2, 3 and 1 (each within the scatter of the next, the first and the last beyond it).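

In this assay, the change from 3,5-dimethoxyphenyl to 3,4,5-trimethoxyphenyl is the first shown that adds a group to this ring instead of moving one, placing a methoxy ortho to two methoxy groups and para to a large group, and it gives a 4.5-fold lower number from compound 1 to compound 4 (0.65 log units; beyond the scatter). The new ring also differs clearly from the 2,3-dimethoxyphenyl ring, with a 3.1-fold lower number from compound 3 to compound 4 (0.49 log units; beyond the scatter), but not from the 2,4-dimethoxyphenyl ring, with a 1.8-fold lower number from compound 2 to compound 4 (0.26 log units; within the scatter), so those two compounds cannot be told apart. Going by these compounds alone, a third methoxy therefore lowers the number when added to the 3,5-dimethoxyphenyl ring, yet compound 2 shows that a ring carrying only two methoxy groups can reach a similar level.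

Nothing available here explains why the added methoxy has this effect. On these data alone, it also remains open whether a hydroxyl, a fluorine atom or an amine at that same place would move the number in the same way as methoxy does.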